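The source may hold more compounds than are shown below. What is called first, only, known or untested is meant among the compounds shown, and "the series" means these compounds.

Working notes on the series. Three compounds share one core; compound 1 `CCOC(=O)C1=C(C)NC(=S)NC1c1cn(C(=O)CNc2ccccc2)c2ccccc12` differs from the other two both at the core and at the aryl group on the amine nitrogen, while compound 2 `CCOC(=O)C1=C(C)NC(=O)NC1c1cn(C(=O)CNc2ccc([N+](=O)[O-])cc2Cl)c2ccccc12` and compound 3 `CCOC(=O)C1=C(C)NC(=O)NC1c1cn(C(=O)CNc2ccccc2[N+](=O)[O-])c2ccccc12` differ only at that aryl group. In a functional assay on MCF7 cells (Homo sapiens) for cytotoxicity, read by MTT assay, with a stated time of 72 h (on this read-out lower numbers stand for stronger inhibition and higher numbers for weaker inhibition), compound 1 gives 52 ug/mL, compound 2 gives 50 ug/mL and compound 3 gives 40 ug/mL. Among the compounds with values here, the one single-point step measured so far, a 1.3-fold lower number from compound 2 to compound 3 (0.10 log units; within the scatter), does not leave the scatter. Compound 3 therefore gives the lowest of the three numbers, but its gaps to compound 2 and to compound 1 are both within the scatter, so no order among the three can be read from this assay.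

The next compound, compound 4 `CCOC(=O)C1=C(C)NC(=O)NC1c1cn(C(=O)CNc2ccccc2N)c2ccccc12`, is obtained from compound 3 by one change: amino in place of nitro on an aromatic carbon. Within the data shown here, the only measured step that bears on this position is the change of the aryl group from compound 2 to compound 3, and that step was within the scatter; no measured pair exchanges the nitro group itself. On this basis the expected step in this assay, a 1.1-fold higher number from compound 3 to compound 4 (0.02 log units; within the scatter), is none beyond the scatter. Compound 4 is accordingly estimated at 42 ug/mL, with a range from 20 ug/mL to 90 ug/mL.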

Compound 4, half-maximal inhibitory concentration: 2.5 ug/mL
Compound 4: the middle estimate sits 17-fold (1.23 log units) above what was measured; the whole stated range lies above it.
By their numbers in this assay, from the lowest: compound 4; then compounds 3, 2 and 1 (each within the scatter of the next).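

In this assay, within the data shown here, the exchange of nitro for amino on this aromatic carbon, ortho to a large group, gives a 16-fold lower number from compound 3 to compound 4 (1.20 log units; beyond the scatter) and so produces the first step that lies beyond the scatter; the earlier change of the aryl group, a 1.3-fold lower number from compound 2 to compound 3 (0.10 log units; within the scatter), had stayed within it and gave no sign that this position could matter so much. The step measured against the other aryl group points the same way, with 2-aminophenyl in place of 2-chloro-4-nitrophenyl giving a 20-fold lower number from compound 2 to compound 4 (1.30 log units; beyond the scatter), so compound 4 stands clearly apart from both nitro-bearing compounds with which it shares the core. Nothing measured here explains why the amino group has this effect.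

Going by these compounds, it remains open whether the step depends on the presence of the amino group or on the loss of nitro, a distinction that a hydrogen, a hydroxyl or an acetamide on the same aromatic carbon would help to draw. On these data alone, it also remains open whether the same exchange would carry the same weight on the core of compound 1.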